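The source may report more compounds than this note shows. Statements on the series, on what has been measured and on what is new or still open speak of the compounds shown alone.

Compound 1 `COc1ccc(C(=O)c2sc(N3CCCC3)nc2N)cc1`: > 200000 nM (a limit)
Compound 2 `Nc1nc(N2CCCC2)sc1C(=O)c1ccc(Br)cc1`: > 200000 nM (a limit)

In a functional assay on CCRF-CEM cells (Homo sapiens) for antiproliferative activity, read by cell counting, with a stated time of 2 days (on this read-out higher numbers stand for weaker inhibition and lower numbers for stronger inhibition), compound 2 gives > 200000 nM as a limit, not a number. Compound 3 `Nc1nc(N2CCCC2)sc1C(=O)c1ccccc1` has not yet been measured. It differs from compound 2 by hydrogen in place of bromo on an aromatic carbon in words: hydrogen in place of bromo on an aromatic carbon. Going by the values given here, the only measured step bearing on this is a step that the two limits leave unreadable from compound 1 to compound 2 and it has no readable size. With the limit of > 200000 nM in this assay, at which 2 of the 2 values shown sit, as the whole record, no step beyond the scatter is expected in this assay and no direction can be given. The estimate is a number no higher from compound 2 to compound 3 (the limit leaves the size open) as the expected step. Compound 3 is expected at 200000 nM with an estimated range of 70000 nM to 400000 nM and it may well come out only as a limit.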

Compound 3, half-maximal inhibitory concentration: > 200000 nM
Compound 3 was reported as a limit (the forecaster's own chance of this, stated with the estimate: 85%); the middle value lies on the limit itself.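

Going by these compounds alone, compound 1, compound 2 and compound 3 are each reported only as a limit, so no step among them can be read. The compounds shown leave open whether methoxy, bromo and hydrogen differ at all in this assay.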